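Sulfonyl variation on the chromone nitrogen: compounds 1 to 4

The source may report more compounds than this note shows. Statements on the series, on what has been measured and on what is new or still open speak of the compounds shown alone.

Measured compounds:
compound 1, `COc1ccc(-c2cc(=O)c3c(OC)cc(OC)cc3n2Cc2ccccc2)cc1`, in a functional assay on HepG2 cells (Homo sapiens) for antiproliferative activity, with a stated time of 72 h (a lower number here means that less compound is needed, a higher number that more compound is needed for the effect), compound 1 gives > 17300 nM, a limit of the assay.
compound 2, `COc1ccc(-c2cc(=O)c3c(OC)cc(OC)cc3n2S(=O)(=O)c2ccc(C=O)cc2)cc1`, in this assay compound 2 gives > 34400 nM, a limit of the assay.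
compound 3, `COc1ccc(-c2cc(=O)c3c(OC)cc(OC)cc3n2S(=O)(=O)c2cccc([N+](=O)[O-])c2)cc1`, in this assay compound 3 gives > 39600 nM, a limit of the assay.

All three values are limits, so compound 3 stands nowhere definite: its number is a limit, as are the two other numbers shown (the limit of > 17300 nM in this assay, at which 1 of the 3 values shown sits, (the limit of > 34400 nM in this assay, at which 1 of the 3 values shown sits), (the limit of > 39600 nM in this assay, at which 1 of the 3 values shown sits)). The step that the two limits leave unreadable from compound 1 to compound 2 and the step that the two limits leave unreadable from compound 2 to compound 3 are both unreadable, since each is bounded on both sides by limits.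

Compound 4, `COc1ccc(-c2cc(=O)c3c(OC)cc(OC)cc3n2S(=O)(=O)c2cc(F)c(F)c(F)c2)cc1`, differs from compound 3 by 3,4,5-trifluorophenyl in place of 3-nitrophenyl on a sulfonyl sulfur. The measured steps that bear on this change are those along the sulfonyl substituent, and neither gives a readable size. No shift beyond the scatter can be argued for in this assay in either direction; the expectation is that compound 4 again reaches only a limit. Compound 4 is therefore estimated at 40000 nM, between 10000 nM and 150000 nM, which means an expected step that the limit leaves unreadable from compound 3 to compound 4.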

Compound 4, half-maximal effective concentration: > 65500 nM
Compound 4 gave a limit, no number (the forecaster's own chance of this, stated with the estimate: 85%); middle value at least 1.6-fold (0.21 log units) away from the limit.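

In this assay compound 4 gives > 65500 nM, a limit of the assay. The steps from compound 2 and compound 3 to compound 4 cannot be read: both ends of each are limits. The compounds shown leave open how these sulfonyl substituents rank against one another.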